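The source may report more compounds than this note shows. Statements on the series, on what has been measured and on what is new or still open speak of the compounds shown alone.

Compound 1 `COc1ccc(C2=NN(C3=NC(=O)/C(=C4\C(=O)Nc5ccc(Br)cc54)S3)C(c3ccc(OC)cc3)C2)cc1` and compound 2 `COc1ccc(C2=NN(C3=NC(=O)/C(=C4\C(=O)Nc5ccc(Cl)cc54)S3)C(c3ccc(OC)cc3)C2)cc1` are built on one core, while compound 3 `COc1ccc(-c2cc(-c3ccc(Cl)cc3)n(C3C(=O)Nc4ccc(Br)cc43)n2)cc1` is built on another; the difference between the two cores is not broken down here. In a functional assay on cells (Cancer cell lines, Homo sapiens) for cytotoxicity, read by sulforhodamine B assay, with a stated time of 48 h (on this read-out higher numbers stand for weaker inhibition of growth and lower numbers for stronger inhibition of growth), compound 1 gives 200 nM, and compound 2 gives 210 nM. The change between them, (chloro in place of bromo on an aromatic carbon), produced a 1.1-fold higher number from compound 1 to compound 2 (0.02 log units; within the scatter). Compound 3, by contrast, gives 7200 nM in this assay, the highest of the three numbers and well apart from both of the others.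

Compound 4 `COc1ccc(-c2cc(-c3ccc(Cl)cc3)n(C3C(=O)Nc4ccc(Cl)cc43)n2)cc1` has not yet been measured. It differs from compound 3 by chloro in place of bromo on an aromatic carbon, the same change that separates compound 1 from compound 2: the group that leaves, the group that enters and the place where the exchange is made are described in identical words for both pairs. Among the measured compounds this exchange is seen only once, so the expectation rests on a single precedent. For compound 4 the expected step is therefore a 1.1-fold higher number from compound 3 to compound 4 (0.02 log units; within the scatter) in this assay, because a 1.1-fold higher number from compound 1 to compound 2 (0.02 log units; within the scatter) stayed within the usual scatter. In this assay, going by the values given here, compound 4 is estimated at 7600 nM, with a likely range from 3800 nM to 15000 nM, the width of that range reflecting that only one earlier instance of the change is available.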

Compound 4, concentration for 50% growth inhibition: 6150 nM
Compound 4: middle estimate off by 1.2-fold (0.09 log units), on the high side, and the stated range covers the measured number.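

In this assay, chloro in place of bromo on an aromatic carbon gave a 1.2-fold lower number from compound 3 to compound 4 (0.07 log units; within the scatter), so on this core too the exchange stayed within the usual scatter. Set beside the earlier instance, the step on the core of compound 3 does not differ from the step on the core of compound 1, and the exchange carried from one core to the other without a visible change in its size: the same change on two cores in this assay, a 1.1-fold higher number (0.02 log units; within the scatter) from compound 1 to compound 2 and a 1.2-fold lower number (0.07 log units; within the scatter) from compound 3 to compound 4, 1.2-fold (0.09 log units) apart, within the scatter of two such steps. Going by these compounds alone, this shows only that one exchange between two halogens at one place made no measurable difference on two cores; it does not show that a larger or different exchange at that place would carry over in the same way, and it says nothing about what separates the two cores.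

The compounds shown hold only bromo and chloro at this place, so it stays open whether fluoro, a nitrile, an amine or a carboxylic acid there would give matching steps on both cores. On these data alone, it also stays open whether the agreement between the two cores would hold for an exchange elsewhere on the molecule, such as an amine in place of a methoxy group.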